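The compounds below may be only part of what the source reports. "The series", "measured", "known", "first", "only" and "open" are said of these compounds alone.

Of the compounds shown here, two built on a shared core have been measured in a functional assay on PC-3 cells (Homo sapiens) for cytotoxicity, read by MTT assay, with a stated time of 72 h; a higher number here means a weaker inhibitor, a lower number a stronger inhibitor. Compound 1 `COc1cc(Nc2nc3ccccc3nc2S(=O)(=O)c2ccccc2)cc(OC)c1` gives 140 nM in this assay, and compound 2 `COc1ccc(S(=O)(=O)c2nc3ccccc3nc2Nc2ccccc2)cc1` gives 1260 nM. Compound 2 therefore has the higher of the two numbers, so it is the weaker inhibitor of the pair, and its gap to compound 1 lies beyond the usual scatter of repeated measurements. The two structures differ from one another in two places at once, so no single change can be credited with that gap.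

Compound 3 `COc1ccc(S(=O)(=O)c2nc3ccccc3nc2Nc2cc(OC)cc(OC)c2)cc1` has not yet been measured. It arises from compound 2 by a single change: 3,5-dimethoxyphenyl in place of phenyl on a nitrogen on an aromatic ring. This brings into compound 3 the same group that compound 1 carries on that nitrogen, while the rest of compound 2 is kept. The change is expected to lower the number, that is to strengthen inhibition, by a step beyond the scatter; this expectation rests on compound 1 carrying this group and giving 140 nM. The estimated step is a 4.2-fold lower number from compound 2 to compound 3 (0.62 log units; beyond the scatter). Compound 3 is expected to give about 300 nM, with a plausible range from 100 nM to 1000 nM.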

Compound 3, half-maximal inhibitory concentration: 6220 nM
Compound 3: the middle estimate sits 21-fold (1.32 log units) below what was measured; the whole stated range lies below it.
By their numbers in this assay, from the lowest: compound 1; then compound 2; then compound 3.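

In this assay, 3,5-dimethoxyphenyl in place of phenyl on a nitrogen on an aromatic ring weakens inhibition, with a 4.9-fold higher number from compound 2 to compound 3 (0.69 log units; beyond the scatter), so this group brings no gain in this setting. With that same group kept on the nitrogen, methoxy in place of hydrogen on an aromatic carbon costs far more, with a 44-fold higher number from compound 1 to compound 3 (1.65 log units; beyond the scatter), which makes this second place a sensitive one in the pair that differs only there. The strength of compound 1 therefore cannot be credited to 3,5-dimethoxyphenyl alone, since compound 3 carries that group and has the highest number of the three.

Nothing available here offers a measured reason for either step. Still open, from the compounds shown here alone, is how the shared core would respond to a smaller change on the nitrogen's ring, such as a single methoxy, and whether a hydroxyl or an amine in place of the methoxy on the aromatic carbon would give a number closer to that of compound 1 or that of compound 3.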